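Methyl in place of oxolan-3-yl: cytotoxicity notes

A few compounds are considered here, and "the series" means these few. Any claim that something is new, unique, unknown or untested is made for them only; others in the source may bear on it.

compound 1 `CC(C)(C)c1cc(/C=N/NC(=O)Nc2cc3c(Nc4ccc(F)c(Cl)c4)ncnc3cc2O[C@H]2CCOC2)cc(C(C)(C)C)c1O` gives 14500 nM
compound 2 `COc1cc2ncnc(Nc3ccc(F)c(Cl)c3)c2cc1NC(=O)N/N=C/c1cccc(Br)c1` gives 27100 nM

Going by the values given here, in a functional assay on MCF7 cells (Homo sapiens) for cytotoxicity, read by MTT assay, with a stated time of 72 h (on this read-out higher numbers stand for weaker inhibition and lower numbers for stronger inhibition), compound 1 stands within the scatter of compound 2, the only other measured compound, so no order can be read between them. Among the compounds with values here, compound 3 `COc1cc2ncnc(Nc3ccc(F)c(Cl)c3)c2cc1NC(=O)N/N=C/c1cc(C(C)(C)C)c(O)c(C(C)(C)C)c1` has methyl in place of oxolan-3-yl on an oxygen on an aromatic ring and no measured step covers this change. Compound 2, which also bears methoxy, gives 27100 nM and offers no sign of a shift, though it differs elsewhere too. The estimated step of a 1.2-fold higher number from compound 1 to compound 3 (0.07 log units; within the scatter) is expected to stay within the scatter, with no firm direction. For compound 3 the expected value is 17000 nM with an estimated range of 7000 nM to 40000 nM in this read-out.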

Compound 3, half-maximal inhibitory concentration: 28300 nM
Compound 3: the middle estimate sits 1.7-fold (0.22 log units) below what was measured; low and high end bracket the measured number.
By their numbers in this assay, from the lowest: compounds 1, 2 and 3 (each within the scatter of the next).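

In this assay, going by these compounds alone, the exchange of (oxolan-3-yl)oxy for methoxy on an oxygen on an aromatic ring gives a 2.0-fold higher number from compound 1 to compound 3 (0.29 log units; within the scatter) and is the only direct reading at this position. With the rest of the structure held constant, removing the oxolan-3-yl ring and its defined stereocentre leaves compound 1 and compound 3 within the scatter, so this read-out does not separate the two groups here. No measured evidence bears on this result. Still open, going by these compounds, is whether an amine or a longer ether chain on this oxygen would give a step beyond the scatter.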